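Adding a Methyl Twice in a Small Solubility Series

This account rests on a few compounds, and the source may have more. Where it says the series, first, only, none or still open, it means among the compounds named here.

The series rests on a shared core carrying a hydroxamic acid chain. Compound 1, `O=C(CCCCCNc1c(Nc2ccccc2)c(=O)c1=O)NO`, gives 2200000 nM in a physicochemical assay for solubility, with a stated time of 24 h, tested at 30 mg/mL; a lower number here means a less soluble compound, a higher number a more soluble compound. Compound 2, `CC(CCCCC(=O)NO)Nc1c(Nc2ccccc2)c(=O)c1=O`, differs from it by methyl in place of hydrogen on a saturated chain carbon bound to a nitrogen on an aromatic ring and a saturated chain carbon, and in this assay compound 2 gives 46000000 nM, which is a 21-fold higher number from compound 1 to compound 2 (1.32 log units; beyond the scatter). Compound 3, `CCC(CCCCC(=O)NO)Nc1c(Nc2ccc(C(F)(F)F)cc2)c(=O)c1=O`, gives 25000000 nM in this assay; the difference between its core and that of compound 1 is not broken down here, and the values of compound 2 and compound 3 lie within the usual scatter of each other.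

Compound 4, `CC(C)C(CCCCC(=O)NO)Nc1c(Nc2ccc(C(F)(F)F)cc2)c(=O)c1=O`, has not been measured. It differs from compound 3 by methyl in place of hydrogen on a saturated chain carbon bound to two saturated chain carbons. Among the compounds with values here, this is the same kind of change as the one from compound 1 to compound 2, but not the same: there the methyl entered on a saturated chain carbon bound to a nitrogen on an aromatic ring and a saturated chain carbon, whereas here it enters on a saturated chain carbon bound to two saturated chain carbons. Within the data shown here, the earlier step was large, and because a 21-fold higher number from compound 1 to compound 2 (1.32 log units; beyond the scatter) is the only precedent for a methyl entering this chain, a rise is expected, though a smaller one is estimated given that the place differs. The expected step is a 1.6-fold higher number from compound 3 to compound 4 (0.20 log units; within the scatter). For compound 4 the estimated value in this assay is 40000000 nM, with a range from 12000000 nM to 70000000 nM.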

Compound 4, solubility: 6300000 nM
For compound 4 the middle estimate is 6.3-fold (0.80 log units) above the measured one; measured number outside the range, below it.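

In this assay the two methyl steps point in opposite directions: the change on the core of compound 1 gives a 21-fold higher number from compound 1 to compound 2 (1.32 log units; beyond the scatter) while the change on the core of compound 3 gives a 4.0-fold lower number from compound 3 to compound 4 (0.60 log units; beyond the scatter) and both steps are printed as beyond the scatter. Within the data shown here, in this series, then, the direction of a step for methyl in place of hydrogen did not hold from one core to the other, and the single earlier step was no safe guide to the later one. This does not show that the core alone turns the step around: the methyl enters on a saturated chain carbon bound to a nitrogen on an aromatic ring and a saturated chain carbon in one pair and on a saturated chain carbon bound to two saturated chain carbons in the other, so with only these two pairs the effect of the core cannot be told apart from that of the place.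

Nothing given here bears on the cause of either step. Still open, as far as these compounds go, is how this assay would read with a longer chain such as propyl in place of the isopropyl of compound 4, with an amine or a carboxylic acid on that chain, and with the same methyl change made at one place on both cores.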